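Three analogues at the assay limit, a fourth expected there

The source may report more compounds than this note shows. Statements on the series, on what has been measured and on what is new or still open speak of the compounds shown alone.

Three compounds share one core and differ only in the group that sits on an amine nitrogen in a ring. Compound 1 `CCCn1c(=O)c2[nH]c(-c3ccc(S(=O)(=O)N4CCN(c5ccc(Cl)cc5)CC4)cc3)nc2n(CC)c1=O` was tested in an assay on CHO cells for displacement of a labelled ligand from adenosine receptor A1 (Homo sapiens), read by scintillation counting, with a stated time of 90 min, in the presence of a further agent that is not named here; a higher number here means a weaker inhibitor, a lower number a stronger inhibitor. In this assay compound 1 returns only a limit, > 1000 nM. Compound 2 `CCCn1c(=O)[nH]c2nc(-c3ccc(S(=O)(=O)N4CCN(c5ccc(Br)cc5)CC4)cc3)[nH]c2c1=O` likewise returns a limit in this assay, > 1000 nM. Compound 3 `CCCn1c(=O)[nH]c2nc(-c3ccc(S(=O)(=O)N4CCN(c5ccccc5)C(C)C4)cc3)[nH]c2c1=O` also gives a limit in this assay, > 1000 nM. Compound 2 therefore stands together with the others at the limit of > 1000 nM in this assay, at which 3 of the 3 values shown sit, and no measured step exists between any two of these compounds, so nothing among them can be set against the usual scatter. Compound 4 `CCCn1c(=O)[nH]c2nc(-c3ccc(S(=O)(=O)N4CCN(c5ccccc5C)CC4)cc3)[nH]c2c1=O` has not yet been measured in this assay. It differs from compound 2 in one place: 2-methylphenyl in place of 4-bromophenyl on an amine nitrogen in a ring. Going by the values given here, with no measured step to lean on, no shift beyond the scatter is expected from compound 2 to compound 4, and a limit is again the likely outcome. The inhibition constant of compound 4 in this assay is estimated at 3000 nM, within 800 nM to 15000 nM. This estimate means a step that the limit leaves unreadable from compound 2 to compound 4.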

Compound 4, inhibition constant: 419 nM
Estimate against measurement, compound 4: 7.2-fold (0.85 log units) above, and the stated range ends above it.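

The group on this amine nitrogen in a ring can move the compound off the limit: 2-methylphenyl in place of 4-bromophenyl gives an at least 2.3-fold lower number from compound 2 to compound 4 (0.37 log units; beyond the scatter) in this assay. The two groups have the same count of heavy atoms and each holds one six-membered aromatic ring of carbon only, so the step comes with no change in those counts, and the value of compound 2 is a limit, which makes the printed size a minimum. Compound 4 is the only one of the four that returns a number rather than a limit: the limit of > 1000 nM in this assay, at which 3 of the 4 values shown sit.

The compounds shown do not separate the arrival of the methyl group from the loss of the bromine, nor show how far the step really reaches. On these data alone, whether 2-methoxyphenyl or a benzyl group in this place would give a lower number remains open.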